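The compounds below may be only part of what the source reports. "The series", "measured", "known", "first", "only" and "open" are said of these compounds alone.

Compound 3 `COc1ccc(Oc2c(/C=N\OCc3c(Cl)c(-c4ccc(Cl)cc4)nn3C)c(C)nn2C)cc1` gives 2010 nM in a functional assay on SGC-7901 cells (Homo sapiens) for antiproliferative activity, read by MTT assay, with a stated time of 72 h (a lower number here means a stronger inhibitor, a higher number a weaker inhibitor), the lowest of the three numbers recorded so far. Compound 2 `Cc1ccc(Oc2c(/C=N\OCc3c(Cl)c(-c4ccc(Cl)cc4)nn3C)c(C)nn2C)cc1` gives 3730 nM, and compound 1 `Cc1nn(C)c(Oc2ccc(F)cc2)c1/C=N\OCc1c(Cl)c(-c2ccc(Cl)cc2)nn1C` gives 4430 nM. The steps between these three are all small: a 1.2-fold lower number from compound 1 to compound 2 (0.07 log units; within the scatter), a 2.2-fold lower number from compound 1 to compound 3 (0.34 log units; beyond the scatter) and a 1.9-fold lower number from compound 2 to compound 3 (0.27 log units; within the scatter). Compound 4 `Cc1nn(C)c(Oc2ccc(OC(F)(F)F)cc2)c1/C=N\OCc1c(Cl)c(-c2ccc(Cl)cc2)nn1C` has not yet been measured. It differs from compound 3 by trifluoromethyl in place of methyl on an oxygen on an aromatic ring. For the measured compounds named here, no measured step swaps methyl for trifluoromethyl on that oxygen; the three steps that bear on the change all alter the substituent at the same part of the shared core, and none moved the number by more than a modest amount, two of them lying within the scatter and only one just beyond it. On that basis a step of similar size is expected in this assay, in either direction, and most likely none beyond the scatter. Compound 4 is therefore estimated at 2500 nM, with a range from 1000 nM to 6500 nM, which means an expected step of a 1.2-fold higher number from compound 3 to compound 4 (0.09 log units; within the scatter).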

Compound 4, half-maximal inhibitory concentration: 3220 nM
Compound 4: middle estimate off by 1.3-fold (0.11 log units), on the low side; the range from low to high includes it.
By their numbers in this assay, from the lowest: compounds 3, 4, 2 and 1 (each within the scatter of the next, the first and the last beyond it).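

In this assay, for the compounds shown here, trifluoromethyl in place of methyl on the oxygen gives a 1.6-fold higher number from compound 3 to compound 4 (0.20 log units; within the scatter), so this change on the oxygen itself, not tested by the earlier compounds, stays within the scatter. Trifluoromethoxy on the aromatic carbon also stays within the scatter of the methyl and fluoro groups there, with a 1.2-fold lower number from compound 2 to compound 4 (0.06 log units; within the scatter) and a 1.4-fold lower number from compound 1 to compound 4 (0.14 log units; within the scatter), which leaves a 2.2-fold lower number from compound 1 to compound 3 (0.34 log units; beyond the scatter) as the only step among the four compounds beyond it. No measurement on hand explains why these steps are so small.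

As far as these compounds go, it remains open whether a group of another kind on this aromatic carbon, such as an amine, a carboxylic acid or a longer alkoxy chain, would move the number further. From the compounds shown here alone, it also remains open whether these small steps would persist if another part of the shared core were changed.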